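A few compounds are considered here, and "the series" means these few. Any claim that something is new, unique, unknown or untested is made for them only; others in the source may bear on it.

Compound 1 `CC(C)=CCC/C(C)=C/CC/C(C)=C/CSC[C@H](NC(=O)CCCCCN1CCN(C)CC1)C(=O)N1CCCC1` stands lowest of the two numbers shown in a functional assay on BXPC-3 cells (Homo sapiens) for cytotoxicity, read by fluorescence, with a stated time of 48 h; a higher number here means that more compound is needed for the effect, a lower number that less compound is needed: compound 1 gives 3200 nM. Compound 2 `CC(C)=CCC/C(C)=C/CC/C(C)=C/CSC[C@H](NC(=O)CCCCCN1CCCC1)C(=O)NC1CCCCC1` gives 12700 nM in this assay, a difference from compound 1 that lies beyond the usual scatter. Compound 3 `CC(C)=CCC/C(C)=C/CC/C(C)=C/CSc1ccccc1C(N)=O` reaches only a limit of the assay and not a number, > 20000 nM, as the evidence notes (the limit of > 20000 nM in this assay, at which 1 of the 3 values shown sits). Compound 4 `CC(C)=CCC/C(C)=C/CC/C(C)=C/CSC[C@H](NC(=O)CCCCCN1CCN(C)CC1)C(=O)NC1CCCCCCC1` is not yet measured. It differs from compound 1 in one place: cyclooctylamino in place of pyrrolidin-1-yl on a carbonyl carbon. Among the measured compounds shown here, no pair of measured compounds shows this change alone; compound 1 and compound 2 differ in two places, so their values show only what they show. Only a small shift toward a higher number is expected here, a 1.6-fold higher number from compound 1 to compound 4 (0.19 log units; within the scatter), which may stay within the scatter. The estimate for compound 4 is 5000 nM, between 1600 nM and 16000 nM.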

Compound 4, half-maximal effective concentration: 7500 nM
Compound 4: the middle estimate sits 1.5-fold (0.18 log units) below what was measured; the measured number falls inside the stated range.
By their numbers in this assay, from the lowest: compound 1; then compounds 4 and 2 (each within the scatter of the next). At a limit, above all of these: compound 3.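

Cyclooctylamino in place of pyrrolidin-1-yl on a carbonyl carbon gives, in this assay, a 2.3-fold higher number from compound 1 to compound 4 (0.37 log units; beyond the scatter). Among the compounds shown here, this is the first reading of that change alone, and it shows that the activity in these cells survives the swap, with a real but limited shift. No measurement shown here bears on the cause of this step.

The compounds shown leave open whether the size of the ring or the amide hydrogen accounts for the step. A cyclopentylamino group on the same carbonyl carbon would separate the two.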